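From 4-ethylphenyl to a trifluoromethylpyridine on sulfur

This account rests on a few compounds, and the source may have more. Where it says the series, first, only, none or still open, it means among the compounds named here.

compound 1 `COc1ccc(SCc2ccc(/C=C/C(=O)Nc3ccccc3N)cc2)cc1OC`: 14.3%
compound 2 `Cc1cc(C)cc(SCc2ccc(/C=C/C(=O)Nc3ccccc3N)cc2)c1`: 8.61%
compound 3 `CCc1ccc(SCc2ccc(/C=C/C(=O)Nc3ccccc3N)cc2)cc1`: 13.2%

These three values come from a functional assay on SMMC-7721 cells (Homo sapiens) for inhibition, read by CCK-8 assay, with a stated time of 72 h, tested at 2 uM; a lower number here means less inhibition of growth, a higher number more inhibition of growth at the concentration tested. Compound 3, at 13.2%, lies within the scatter of both other compounds, so the three cannot be ranked on these numbers.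

The next compound, compound 4 `Nc1ccccc1NC(=O)/C=C/c1ccc(CSc2ccc(C(F)(F)F)cn2)cc1`, keeps the shared core and alters only the group on the sulfur: 5-(trifluoromethyl)pyridin-2-yl in place of 4-ethylphenyl on a sulfur. In words, 5-(trifluoromethyl)pyridin-2-yl stands in place of 4-ethylphenyl, so a ring of carbon only gives way to an aromatic ring with 1 hetero atom.

Among the measured compounds shown here, three measured steps bear on this change, since each swaps the group at the same place: a number 5.7 percentage points lower from compound 1 to compound 2 (within the scatter), a number 1.1 percentage points lower from compound 1 to compound 3 (within the scatter) and a number 4.6 percentage points higher from compound 2 to compound 3 (within the scatter). All of them are modest in size, and none leaves the scatter. None of them, however, introduces a hetero atom into that ring or brings in fluorine, so the data offer only indirect guidance and the range must stay wide. No step beyond the scatter is expected, and no direction can be favoured. The expected step is a number 1.2 percentage points lower from compound 3 to compound 4 (within the scatter). In this assay, compound 4 is estimated at 12%, with an expected range from 3% to 27%.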

Compound 4, percent growth inhibition at one concentration: 12.1%
Beside the measured number, compound 4's estimate is 0.1 percentage points below it; low and high end bracket the measured number.
By their numbers in this assay, from the lowest: compounds 2, 4, 3 and 1 (each within the scatter of the next).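

In this assay, compound 4 is the only one shown with a hetero atom in the ring on the sulfur and the only one with fluorine, and 5-(trifluoromethyl)pyridin-2-yl in place of 4-ethylphenyl gives a number 1.1 percentage points lower from compound 3 to compound 4 (within the scatter). Its comparisons with the other two groups give a number 3.5 percentage points higher from compound 2 to compound 4 (within the scatter) and a number 2.2 percentage points lower from compound 1 to compound 4 (within the scatter), so all of its steps stay inside the usual scatter. Even this larger change of ring type therefore produces no measurable separation in this read-out, and the four compounds still cannot be ranked, while no measured property of these groups is available to account for the outcome.

As far as these compounds go, because the hetero atom and the trifluoromethyl group enter together, their separate contributions stay open, and a plain pyridin-2-yl ring or a trifluoromethylphenyl ring would be needed to pull them apart. Every group shown on the sulfur is also a six-membered aromatic ring, so it remains unknown whether an amine, a carboxylic acid or a simple alkyl chain at this place would give a step beyond the scatter in this assay.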